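Changing the amide tail of a vitamin D receptor agonist

The source may report more compounds than this note shows. Statements on the series, on what has been measured and on what is new or still open speak of the compounds shown alone.

Four compounds share one core. Compound 1 `CCn1c(C(=O)On2nnc3ccccc32)ccc1C(CC)(CC)c1ccc(C#CC(O)(CC)CC)c(C)c1` in an assay on cells for agonist activity at vitamin D3 receptor (Homo sapiens), read by microscopy (a lower number here means that less compound is needed, a higher number that more compound is needed for the effect), gives only a limit, > 50 nM. Compound 2 `CCn1c(C(=O)NCCCO)ccc1C(CC)(CC)c1ccc(C#CC(O)(CC)CC)c(C)c1` gives 137 nM in this assay. Compound 3 `CCn1cc(C(CC)(CC)c2ccc(C#CC(O)(CC)CC)c(C)c2)cc1C(=O)NCC(=O)OC` gives 288 nM in this assay, the higher of the two numbers, and its gap to compound 2 lies beyond the scatter. Among the compounds with values here, the only measured step, a step that the limit leaves unreadable from compound 1 to compound 2, cannot be read because of the limit of > 50 nM in this assay, at which 1 of the 3 values shown sits. Compound 4 `CCn1cc(C(CC)(CC)c2ccc(C#CC(O)(CC)CC)c(C)c2)cc1C(=O)N[C@@H](C(=O)O)C(C)C` differs from compound 3 by 1-carboxy-2-methylpropyl in place of (methoxycarbonyl)methyl on an amide-type nitrogen. Within the data shown here, no measured step touches this change, so no shift beyond the scatter is expected. Compound 4 is estimated to give about 300 nM, between 100 nM and 900 nM, in this assay. The expected step is a 1.0-fold higher number from compound 3 to compound 4 (0.02 log units; within the scatter), within the scatter.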

Compound 4, half-maximal effective concentration: 68.3 nM
Estimate against measurement, compound 4: 4.4-fold (0.64 log units) above; measured number outside the range, below it.
By their numbers in this assay, from the lowest: compounds 4 and 2 (each within the scatter of the next); then compound 3.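

Replacing (methoxycarbonyl)methyl with 1-carboxy-2-methylpropyl on the amide-type nitrogen gives a 4.2-fold lower number from compound 3 to compound 4 (0.62 log units; beyond the scatter) in this assay. Within the data shown here, this is the first readable step at this position, and it shows that the group on this nitrogen can change how much compound is needed. The entering group carries a free carboxylic acid where the leaving group has a methyl ester, and it also has a branched chain, so this one step cannot separate the two.

On these data alone, how an amine on a chain at this nitrogen would compare remains open. Compound 1 gives only a limit, so its step to compound 2 cannot be read: the limit of > 50 nM in this assay, at which 1 of the 4 values shown sits.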